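The source may report more compounds than this note shows. Statements on the series, on what has been measured and on what is new or still open speak of the compounds shown alone.

Values in a functional assay on HepG2 cells for inhibition of squalene monooxygenase (Homo sapiens); a lower number here means a stronger inhibitor, a higher number a weaker inhibitor:

compound 1, `CCN(C/C=C/C#CC(C)(C)C)Cc1cccc(OCCN(C)S(=O)(=O)c2ccc(F)cc2)c1`: 255 nM
compound 2, `CCN(C/C=C/C#CC(C)(C)C)Cc1cccc(OCCN(C)S(=O)(=O)c2nccs2)c1`: 170 nM
compound 3, `CCN(C/C=C/C#CC(C)(C)C)Cc1cccc(OCCN(CC)S(=O)(=O)c2cccs2)c1`: 90 nM

Compound 2 has the numbers of compound 1 and compound 3 on either side of it, but the step of a 1.5-fold lower number from compound 1 to compound 2 (0.18 log units; within the scatter) and the step of a 1.9-fold lower number from compound 2 to compound 3 (0.28 log units; within the scatter) both stay within the scatter, so these three numbers do not separate compound 2 from the other two.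

Compound 4, `CCN(C/C=C/C#CC(C)(C)C)Cc1cccc(OCCN(C)S(=O)(=O)c2ccc(-c3ccsc3)s2)c1`, differs from compound 2 by 5-(thiophen-3-yl)thiophen-2-yl in place of 1,3-thiazol-2-yl on a sulfonyl sulfur. Among the compounds with values here, two measured steps bear on this change. The step of a 1.5-fold lower number from compound 1 to compound 2 (0.18 log units; within the scatter) exchanges the group on the same sulfonyl sulfur and stays within the scatter. The step of a 1.9-fold lower number from compound 2 to compound 3 (0.28 log units; within the scatter) replaces the whole sulfonamide piece, the 1,3-thiazol-2-yl included, and likewise stays within the scatter. Neither step gives ground for a move beyond the scatter in this assay, though the entering group is larger than anything yet measured on that sulfur, which widens the range.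

For compound 4 the expected step is therefore a 1.1-fold lower number from compound 2 to compound 4 (0.05 log units; within the scatter), not beyond the scatter. The estimate for compound 4 is 150 nM, with a range from 50 nM to 450 nM.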

Compound 4, half-maximal inhibitory concentration: 210 nM
For compound 4 the middle estimate is 1.4-fold (0.15 log units) below the measured one, and the stated range covers the measured number.
By their numbers in this assay, from the lowest: compounds 3, 2, 4 and 1 (each within the scatter of the next, the first and the last beyond it).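

On the sulfonyl sulfur, in this assay, going from 5 to 10 heavy atoms and from one five-membered aromatic ring to two does not take the number beyond the scatter (a 1.2-fold higher number from compound 2 to compound 4 (0.09 log units; within the scatter)). The same holds against the 4-fluorophenyl group (a 1.2-fold lower number from compound 1 to compound 4 (0.08 log units; within the scatter)), so among compound 1, compound 2 and compound 4 this position shows no separation, even with the largest group so far. No measurement on hand offers an explanation for this result.

As far as these compounds go, it remains open whether a group of another kind on this sulfur, such as an amine or a carboxylic acid, would move the number beyond the scatter. Also open, from the compounds shown here alone, is what the ethyl on the sulfonamide nitrogen contributes alone, as compound 3 carries it together with a different group on the sulfonyl sulfur.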